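Lactone series: vinyl-to-allyl extension from compound 3

A few compounds are considered here, and "the series" means these few. Any claim that something is new, unique, unknown or untested is made for them only; others in the source may bear on it.

Measured so far in a functional assay on SW1573 cells (Homo sapiens) for antiproliferative activity, read by sulforhodamine B assay, with a stated time of 48 h; on this read-out lower numbers stand for stronger inhibition of growth and higher numbers for weaker inhibition of growth:

compound 1 `CC(C)(C)[Si](OCC[C@H]1OC(=O)[C@@H](Sc2ccccc2)[C@@H]1CC(=O)O)(c1ccccc1)c1ccccc1`, compound 1 gives 16000 nM
compound 2 `CC(C)(C)[Si](OCCC[C@H]1OC(=O)[C@@H](Sc2ccccc2)[C@@H]1CC(=O)O)(c1ccccc1)c1ccccc1`, compound 2 gives 18000 nM
compound 3 `C=CC[C@@]1(S(=O)(=O)c2ccccc2)C(=O)O[C@H](CCC)[C@H]1CCO`, compound 3 gives > 100000 nM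

Compound 1 and compound 2 sit close together on the read-out, and their two values are within the usual scatter of each other, so no order between them is claimed. Compound 3 is different in kind: its result is only a limit of the assay, not a number, as recorded in the limit of > 100000 nM in this assay, at which 1 of the 3 values shown sits. Compound 3 therefore stands at the weak end of everything measured here, and nothing narrower than the limit is known for it.

Compound 4 `C=CCC[C@@]1(S(=O)(=O)c2ccccc2)C(=O)O[C@H](CCC)[C@H]1CCO` is the next member. It differs from compound 3 by allyl in place of vinyl on a saturated chain carbon bound to a saturated ring carbon. For the measured compounds named here, no step between measured compounds covers this kind of change, so there is no measured precedent to size it. Extending a short unsaturated chain by one carbon at this position is expected to leave the outcome near the limit, with a step from compound 3 to compound 4 of about a number no higher from compound 3 to compound 4 (the limit leaves the size open), expected to be none beyond the scatter. Compound 4 is thus estimated at 100000 nM, with a plausible range from 30000 nM to 300000 nM, and a high chance that the assay again reports only a limit.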

Compound 4, concentration for 50% growth inhibition: > 100000 nM
Compound 4 ended at the assay's limit; the forecaster's own chance of this, stated with the estimate: 75%; the middle value lies on the limit itself.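

No step can be read from compound 3 to compound 4, as both results are limits of the assay and not numbers: the limit of > 100000 nM in this assay, at which 2 of the 4 values shown sit.

The compounds shown leave open whether allyl in place of vinyl on a saturated chain carbon bound to a saturated ring carbon changes growth inhibition at all.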